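A few compounds are considered here, and "the series" means these few. Any claim that something is new, unique, unknown or untested is made for them only; others in the source may bear on it.

Measured compounds:
Compound 1 `O=CN1CCN(c2ccc(Cl)cc2)C1=S`: 17500 nM
Compound 2 `COc1cc(C(=O)N2CCN(C=O)C2=S)cc(OC)c1OC`: 19900 nM
Compound 3 `N#C/C(=C\N1CCN(C(=O)c2ccco2)C1=S)C(=O)Nc1ccc(Cl)cc1`: 16500 nM

All three were tested in a functional assay on UACC-257 cells (Homo sapiens) for inhibition, read by sulforhodamine B assay, with a stated time of 48 h; a lower number here means a stronger inhibitor of growth, a higher number a weaker inhibitor of growth. Compound 1 sits among the three numbers with compound 3 nearest and compound 2 furthest, yet both of those gaps lie within the scatter, so the three compounds cannot be told apart on this evidence.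

Compound 4 `O=CN1CCN(c2ccc(Cl)c(Cl)c2)C1=S` has not been measured. It differs from compound 1 by chloro in place of hydrogen on an aromatic carbon. For the measured compounds named here, no pair of measured compounds shows such a change, so there is no measured step to set its size. The expected step in this assay is a 1.3-fold lower number from compound 1 to compound 4 (0.10 log units; within the scatter), which is not beyond the scatter. Compound 4 is therefore estimated at 14000 nM, with a range from 5000 nM to 40000 nM.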

Compound 4, concentration for 50% growth inhibition: 17700 nM
Compound 4: middle estimate off by 1.3-fold (0.10 log units), on the low side, within the range that was stated.
By their numbers in this assay, from the lowest: compounds 3, 1, 4 and 2 (each within the scatter of the next).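

In this assay, chloro in place of hydrogen on an aromatic carbon, ortho to a chloro group and meta to a group of 8 heavy atoms, gives a 1.0-fold higher number from compound 1 to compound 4 (0.00 log units; within the scatter). This is the only step among the compounds shown that changes one place alone, and it lies within the scatter, so this change at this position has no measurable effect here. Nothing measured on these compounds offers an explanation for this result. As far as these compounds go, whether an amine or a carboxylic acid on this same aromatic carbon would give a step beyond the scatter remains open.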